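Swapping the Side Chain of Compound 2 for an Ester

This account rests on a few compounds, and the source may have more. Where it says the series, first, only, none or still open, it means among the compounds named here.

Of the compounds shown here, three sharing one core have been tested in a functional assay on the whole organism (Tail, strain ICR) with Mus musculus as the target, in the tail flick test, with a stated time of 60 min, at a dose of 25 umol/kg by the oral route; on this read-out higher numbers stand for a stronger effect at the one dose given and lower numbers for a weaker effect. Compound 1 `NC(=O)CC[C@H](NC(=O)CN(c1ncnc2c1ncn2C1CCCCO1)C1CC1)C(=O)OCc1ccccc1` gives 39.4%, compound 2 `CC[C@H](C)[C@H](NC(=O)CN(c1ncnc2c1ncn2C1CCCCO1)C1CC1)C(=O)OCc1ccccc1` gives 27.4%, and compound 3 `CC[C@H](C)[C@H](NC(=O)CN(c1nc(Cl)nc2[nH]cnc12)C1CC1)C(=O)OCc1ccccc1` gives 40.6%. Compound 2 thus stands lowest of the three numbers; its gap to compound 1 and its gap to compound 3 are each beyond the scatter.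

Compound 4 `O=C(CN(c1ncnc2c1ncn2C1CCCCO1)C1CC1)N[C@@H](CC(=O)OCc1ccccc1)C(=O)OCc1ccccc1` has not yet been measured. It differs from compound 2 in one place: (benzyloxycarbonyl)methyl in place of sec-butyl on a saturated chain carbon bound to an amide-type nitrogen and a carbonyl carbon.

For the measured compounds named here, only one measured step touches this position. The step of a number 12 percentage points lower from compound 1 to compound 2 (beyond the scatter) shows that exchanging 2-carbamoylethyl for sec-butyl lowered the number modestly. Going by the values given here, compound 4 replaces the same sec-butyl with another chain, (benzyloxycarbonyl)methyl, so the one comparison at hand points back upward, though no measured step uses this exact group, and the size is uncertain.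

A modest rise in this assay is therefore expected, as the estimated step of a number 8.6 percentage points higher from compound 2 to compound 4 (within the scatter). For compound 4 the expected value is 36%, with a range from 22% to 50%.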

Compound 4, a percentage reported as activity, at one dose (the size of the read-out at that dose, not a potency): 38.2%
Compound 4: middle estimate off by 2.2 percentage points, on the low side, within the range that was stated.
By their numbers in this assay, from the lowest: compound 2; then compounds 4, 1 and 3 (each within the scatter of the next).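

Replacing sec-butyl with (benzyloxycarbonyl)methyl gives a number 10.8 percentage points higher from compound 2 to compound 4 (beyond the scatter) in this assay, which makes this the second chain at this position to stand clear of sec-butyl, and this one brings a six-membered aromatic ring with it. Set against the other chain, the step is a number 1.2 percentage points lower from compound 1 to compound 4 (within the scatter), so the two chains cannot be told apart here, even though one ends in a carbamoyl group and the other in a benzyl ester. Both of these chains hold a carbonyl and sec-butyl does not, but that link rests on just three groups, and no measurement shown here gives a reason for the shift.

A carboxylic acid in place of the benzyl ester, or a plain hexyl chain with no carbonyl at all, would help show whether the carbonyl goes with the higher number or whether sec-butyl is simply the odd one out. From the compounds shown here alone, the read-out also comes from a single dose, so how these compounds would rank in potency stays open.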